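A few compounds are considered here, and "the series" means these few. Any claim that something is new, unique, unknown or untested is made for them only; others in the source may bear on it.

Compound 1 `CC(C)CCn1cnc2c(Nc3ccc(Cl)cc3)nc(N[C@H]3CC[C@H](N)CC3)nc21` and compound 2 `CC(C)CCn1cnc2c(Nc3ccccc3)nc(N[C@H]3CC[C@H](N)CC3)nc21` share one core and differ in a single place, (hydrogen in place of chloro on an aromatic carbon). In a functional assay on HCC827 cells (Homo sapiens) for inhibition, read by fluorescence, with a stated time of 72 h (a higher number here means a weaker inhibitor of growth, a lower number a stronger inhibitor of growth), compound 1 gives 10200 nM, while compound 2 gives 21700 nM; the step of a 2.1-fold higher number from compound 1 to compound 2 (0.33 log units; beyond the scatter) is recorded as beyond the scatter. Compound 3 `CCCCn1cnc2c(Nc3cccc(Cl)c3)nc(N[C@H]3CC[C@H](N)CC3)nc21` carries a different core, and the difference between the two cores is not broken down here. In this assay compound 3 gives 7200 nM, the lowest of the three numbers, though its gap to compound 1 lies within the scatter and only its gap to compound 2 lies beyond it.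

Compound 4 `CCCCn1cnc2c(Nc3ccccc3)nc(N[C@H]3CC[C@H](N)CC3)nc21` has not yet been measured. It differs from compound 3 in one place, (hydrogen in place of chloro on an aromatic carbon). This is the same kind of change as from compound 1 to compound 2, but not the same change: in compound 1 the leaving group sits para to a large group, whereas in compound 3 it sits meta to a large group. Among these compounds the change occurs twice, and only the first occurrence carries a measurement.

For compound 4 the expected step is a 2.1-fold higher number from compound 3 to compound 4 (0.32 log units; beyond the scatter), resting on the single measured parallel a 2.1-fold higher number from compound 1 to compound 2 (0.33 log units; beyond the scatter) and on the value of compound 3 7200 nM. Compound 4 is therefore estimated at 15000 nM in this assay. The range expected for compound 4 runs from 7000 nM to 32000 nM, wide because the step of a 2.1-fold higher number from compound 1 to compound 2 (0.33 log units; beyond the scatter) is the only measured parallel and sits at a different place on the ring.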

Compound 4, concentration for 50% growth inhibition: 9000 nM
Beside the measured number, compound 4's estimate is 1.7-fold (0.22 log units) above it; low and high end bracket the measured number.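

In this assay, hydrogen in place of chloro on the core of compound 3 gives a 1.3-fold higher number from compound 3 to compound 4 (0.10 log units; within the scatter), so on this core the change leaves the number within the scatter, whereas on the core of compound 1 it went beyond it; set side by side, the two steps cannot be told apart: the same change on two cores in this assay, a 2.1-fold higher number (0.33 log units; beyond the scatter) from compound 1 to compound 2 and a 1.3-fold higher number (0.10 log units; within the scatter) from compound 3 to compound 4, 1.7-fold (0.23 log units) apart, within the scatter of two such steps. Among the compounds shown here, this shows that the result on the core of compound 3 is compatible with the earlier step, but it does not show that the change carries over reliably, as the series offers only two pairs, and the chloro sits at a different place on the ring in each. For the compounds shown here, the one other single change, hydrogen in place of methyl on a saturated chain carbon, gives a 2.4-fold lower number from compound 2 to compound 4 (0.38 log units; beyond the scatter), and this too rests on a single pair.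

The compounds shown leave open whether the chloro would give the same step at one fixed place on the ring with only the chain changed, for instance a 3-chlorophenyl group paired with the chain of compound 1. They also leave open how a fluoro, methoxy or nitrile group in place of the chloro, or a longer chain in place of the butyl chain, would read in this assay.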